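The source may hold more compounds than are shown below. What is called first, only, known or untested is meant among the compounds shown, and "the series" means these compounds.

Working notes on the urea series.

Two members of the series have a number in an assay on isolated protein for activation of Nicotinamide phosphoribosyltransferase (Homo sapiens); a lower number here means that less compound is needed, a higher number that more compound is needed for the effect. Compound 1, `CCOC(=O)c1ccc(NC(=O)NCc2cocn2)cc1`, gives 27600 nM in this assay. Compound 2, `CN(C1CCCC1)S(=O)(=O)c1ccc(NC(=O)NCc2ccncc2)cc1`, gives 123 nM in this assay, the lower of the two numbers; its gap to compound 1 lies well beyond the scatter. Both carry the same urea linker and the same aryl core, and they differ at the heteroaryl methyl end as well as in the para substituent of the core, so no single change can be read from this pair.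

The next step keeps everything in compound 2 except the group on the sulfonamide nitrogen. Compound 3, `CN(C)S(=O)(=O)c1ccc(NC(=O)NCc2ccncc2)cc1`, shows (methyl in place of cyclopentyl on a sulfonamide nitrogen). Among the measured compounds shown here, with no measured pair of this kind available, the expected direction rests on general experience only: the cyclopentyl is not a small group, and trimming it to methyl is expected to cost some potency, with the step from compound 2 to compound 3 estimated at a 3.7-fold higher number from compound 2 to compound 3 (0.56 log units; beyond the scatter), beyond the scatter but not large. For compound 3 the expected value in this assay is 450 nM, with a range of 130 nM to 1600 nM.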

Compound 3, half-maximal effective concentration: 3110 nM
Compound 3: the middle estimate sits 6.9-fold (0.84 log units) below what was measured; measured number above the stated range.
By their numbers in this assay, from the lowest: compound 2; then compound 3; then compound 1.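

The group on the sulfonamide nitrogen can now be read on its own: in this assay, methyl in place of cyclopentyl gives a large step (a 25-fold higher number from compound 2 to compound 3 (1.40 log units; beyond the scatter)). Among the compounds shown here, this is the first change confined to one place, and it shows that the number at this position depends strongly on which of these two groups the nitrogen carries. Nothing available here bears on the origin of this step.

As far as these compounds go, with only cyclopentyl and methyl compared on this nitrogen, it remains open whether the ring itself or simply the carbon count goes with the lower number; an open pentyl chain, with the same count of carbons as cyclopentyl, would separate the two readings, while ethyl, isopropyl or cyclohexyl would show how the number runs between and beyond these groups. Also open, from the compounds shown here alone, is whether an amine or a hydroxyl on the cyclopentyl ring would be compatible with the low number of compound 2, and whether the step holds when the heteroaryl methyl end is changed.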